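Swapping a Propyl Carbamate for a Phenyl Carbamate

This account rests on a few compounds, and the source may have more. Where it says the series, first, only, none or still open, it means among the compounds named here.

Two carbamates built on the same selenocyanate-bearing core have been tested. In a functional assay on HTB-54 cells (Homo sapiens) for cytotoxicity, read by MTT assay, with a stated time of 72 h (on this read-out lower numbers stand for stronger inhibition of growth and higher numbers for weaker inhibition of growth), compound 1 `N#C[Se]c1ccc(NC(=O)Oc2ccc(F)cc2)cc1` gives 25000 nM, and compound 2 `CCCOC(=O)Nc1ccc([Se]C#N)cc1` gives 28900 nM. Compound 2 holds the higher of these two numbers, yet its gap to compound 1 lies within the usual scatter, so the two cannot be told apart on this read-out. The next compound, compound 3 `N#C[Se]c1ccc(NC(=O)Oc2ccccc2)cc1`, has not yet been measured. It differs from compound 2 in one place: phenyl in place of propyl on an oxygen next to a carbonyl group. Among the compounds with values here, with only two measured compounds and no step between them, no direction for this change can be read from the data, and a step that stays within the scatter, in either direction, is the most that can be expected. The expected change is a 1.2-fold lower number from compound 2 to compound 3 (0.08 log units; within the scatter). For compound 3 in this assay the estimate is 24000 nM, within a range from 10000 nM to 60000 nM.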

Compound 3, concentration for 50% growth inhibition: 26200 nM
Compound 3: middle estimate off by 1.1-fold (0.04 log units), on the low side; low and high end bracket the measured number.
By their numbers in this assay, from the lowest: compounds 1, 3 and 2 (each within the scatter of the next).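

In this assay, phenyl in place of propyl on an oxygen next to a carbonyl group gives a 1.1-fold lower number from compound 2 to compound 3 (0.04 log units; within the scatter) and so shows that, for these two compounds, a ring and an open chain at this position cannot be told apart. The comparison of the two phenyl carbamates adds a second change: hydrogen in place of fluoro on an aromatic carbon gives a 1.0-fold higher number from compound 1 to compound 3 (0.02 log units; within the scatter) and shows that the fluoro group makes no readable difference here either. Nothing available explains why these values lie so close together.

Still open is whether any group at this position can move the number beyond the scatter, since only propyl, phenyl and fluorophenyl are shown. A longer chain in place of propyl, or an amine or a carboxylic acid on the phenyl ring, could test this.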